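This account rests on a few compounds, and the source may have more. Where it says the series, first, only, none or still open, it means among the compounds named here.

Of the compounds shown here, two built on one shared core have numbers so far in a functional assay on the whole organism with Mus musculus as the target; on this read-out lower numbers stand for an effect already at smaller amounts and higher numbers for an effect only at larger amounts of compound. Compound 1 `COc1ccc(-c2nc3cccnc3n2CC(=O)N(C)C)cc1` gives 39.5 mg/kg, and compound 2 `CN(C)C(=O)Cn1c(-c2ccc(F)cc2)nc2cccnc21` gives 40.5 mg/kg. Compound 2 therefore cannot be separated from compound 1: the measured change is a 1.0-fold higher number from compound 1 to compound 2 (0.01 log units; within the scatter), so the pair counts as level.

The next compound, compound 3 `CN(C)C(=O)Cn1c(-c2ccsc2)nc2cccnc21`, keeps the shared core and the (dimethylcarbamoyl)methyl group of compound 2 and alters one substituent: thiophen-3-yl in place of 4-fluorophenyl on an aromatic carbon. Put simply, thiophen-3-yl stands in place of 4-fluorophenyl on an aromatic carbon.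

Within the data shown here, only one measured comparison bears on this. Fluoro in place of methoxy on an aromatic carbon gave a 1.0-fold higher number from compound 1 to compound 2 (0.01 log units; within the scatter). That comparison exchanged a small substituent and left the aromatic ring itself in place, so it is only weak evidence here. Among the measured compounds shown here, no measured compound shows what a five-membered aromatic ring does at this place, so no direction can be argued from the data.

The expected change is a 1.0-fold lower number from compound 2 to compound 3 (0.01 log units; within the scatter), meaning no step beyond the scatter, though with real uncertainty. The estimate for compound 3 is 40 mg/kg, with an expected range from 15 mg/kg to 100 mg/kg.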

Compound 3, dose for half-maximal effect: 38 mg/kg
Compound 3: middle estimate off by 1.1-fold (0.02 log units), on the high side, within the range that was stated.
By their numbers in this assay, from the lowest: compounds 3, 1 and 2 (each within the scatter of the next).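

At this aromatic carbon, which lies between two ring nitrogen atoms, the six-membered carbon ring of 4-fluorophenyl is exchanged for the five-membered, sulfur-containing ring of thiophen-3-yl, and this assay shows only a 1.1-fold lower number from compound 2 to compound 3 (0.03 log units; within the scatter). The earlier step changed a small substituent on a ring that stayed in place, whereas this one replaces the ring itself, so the read-out can stay level through a change in ring size and ring atoms as well. No measured information on these groups is available to explain this level result.

Going by these compounds, all three groups at this carbon are aromatic rings, so it remains open whether the number would stay level with a saturated ring such as cyclohexyl, a simple chain such as n-butyl, or a basic group such as an aminomethyl group. The (dimethylcarbamoyl)methyl group is also the same throughout, so these compounds say nothing about how the read-out would respond if its dimethylamide were replaced by a carboxylic acid or its chain were lengthened.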